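Removal of one methoxy on the carbonyl-side aryl

The source may report more compounds than this note shows. Statements on the series, on what has been measured and on what is new or still open speak of the compounds shown alone.

Working notes on the series. Among the compounds with values here, compound 2 `COc1ccc(C(=O)/C=C/c2cc(-c3cc(OC)c(OC)c(OC)c3)n[nH]2)cc1OC` stands highest of the two numbers so far in a functional assay on HCT-116 cells (Homo sapiens) for cytotoxicity, read by sulforhodamine B assay, with a stated time of 48 h, tested at 10 uM; on this read-out higher numbers stand for a weaker effect at the one concentration tested and lower numbers for a stronger effect: compound 2 gives -65%, while compound 1 `COc1cc(-c2cc(/C=C/C(=O)c3ccc(N)cc3)[nH]n2)cc(OC)c1OC` gives -78%. Within the data shown here, the one measured step, a number 13 percentage points higher from compound 1 to compound 2 (beyond the scatter), changed the whole aryl on the carbonyl carbon. Compound 3 `COc1ccc(C(=O)/C=C/c2cc(-c3cc(OC)c(OC)c(OC)c3)n[nH]2)cc1` is the next member and differs from compound 2 by hydrogen in place of methoxy on an aromatic carbon. This change sits on the same aryl that was exchanged in the step from compound 1 to compound 2, so that step is the only one with any bearing, and it was modest; it does not show what removing a single methoxy from this ring does, so no direction can be read from it. The expectation for compound 3 in this assay is therefore a step of no change at the digits printed from compound 2 to compound 3 (within the scatter), that is, no change beyond the scatter. Compound 3 is accordingly estimated at -65%, with a range from -85% to -45% to cover the lack of a directly comparable step.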

Compound 3, a percentage reported as activity, at one concentration (the size of the read-out at that concentration, not a potency): -22%
For compound 3 the middle estimate is 43 percentage points below the measured one, outside the stated range (above it).
By their numbers in this assay, from the lowest: compound 1; then compound 2; then compound 3.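

In this assay, the change from 3,4-dimethoxyphenyl to 4-methoxyphenyl gives a number 43 percentage points higher from compound 2 to compound 3 (beyond the scatter), so the single methoxy ortho to a methoxy group carries much of the effect of compound 2, which the earlier exchange of the whole aryl could not isolate. The group left on the aryl also counts, since the change from amino to methoxy gives a number 56 percentage points higher from compound 1 to compound 3 (beyond the scatter); compound 1 therefore goes against any reading that a second substituent on this aryl is needed for a strong effect, as it keeps a strong read-out with the amino group alone. Nothing among the available data accounts for either step.

On these data alone, it remains open whether the effect lost in compound 3 depends on methoxy itself or would also be kept by a hydroxyl, a chlorine or an ethoxy on the same aromatic carbon. As far as these compounds go, it is also open whether an amino group on that carbon, alongside the methoxy of compound 3, would move the read-out toward that of compound 1, and all of this rests on one cell line at one concentration.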